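Alkoxy Groups on a Biaryl Nitrile and Receptor Inhibition

A few compounds are considered here, and "the series" means these few. Any claim that something is new, unique, unknown or untested is made for them only; others in the source may bear on it.

Compound 1, `Cc1ccc2ccc(-c3cccc(C#N)c3)cc2n1`, gives 7.7 nM in a functional assay on CHO cells for inhibition of metabotropic glutamate receptor 5 (Rattus norvegicus), read by FLIPR and calcium flux; a higher number here means a weaker inhibitor, a lower number a stronger inhibitor.
Compound 2, `COCc1cc(C#N)cc(-c2ccc3ccc(C)nc3c2)c1`, gives 2 nM in this assay.
Compound 3, `Cc1ccc2ccc(-c3cc(C#N)cc(OC(F)(F)F)c3)cc2n1`, gives 75 nM in this assay.

The three compounds share one core and differ only in the group on a single aromatic carbon of the nitrile-bearing ring. Compound 3, which carries trifluoromethoxy there, gives the highest number of the three in this assay: a 9.7-fold higher number from compound 1 to compound 3 (0.99 log units; beyond the scatter), and a 38-fold higher number from compound 2 to compound 3 (1.57 log units; beyond the scatter). The step with methoxymethyl goes the other way, since a 3.9-fold lower number from compound 1 to compound 2 (0.59 log units; beyond the scatter).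

Compound 4, `Cc1ccc2ccc(-c3cc(C#N)cc(OCC(C)C)c3)cc2n1`, has not yet been tested. Its change from compound 3 is isobutyl in place of trifluoromethyl on an oxygen on an aromatic ring. Within the data shown here, none of the measured steps makes this exact exchange, but the two steps from compound 1 show that a group at this carbon can move the number in either direction, modestly or largely. Compound 4 is therefore expected to land between the extremes, with the step of a 2.5-fold lower number from compound 3 to compound 4 (0.40 log units; beyond the scatter) estimated as a lower number than compound 3 but not reaching compound 2. The estimate for compound 4 in this assay is 30 nM, within a range from 6 nM to 150 nM.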

Compound 4, half-maximal inhibitory concentration: 12000 nM
Compound 4: middle estimate off by 400-fold (2.60 log units), on the low side; measured number above the stated range.
By their numbers in this assay, from the lowest: compound 2; then compound 1; then compound 3; then compound 4.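

In this assay, an isobutoxy group on this aromatic carbon moves the number much further than any group seen before, and in the upward direction (a 1600-fold higher number from compound 1 to compound 4 (3.19 log units; beyond the scatter)). Against methoxymethyl, the other group with an oxygen in it, the gap is wider still (a 6000-fold higher number from compound 2 to compound 4 (3.78 log units; beyond the scatter)), so having an oxygen in the group at this carbon does not on its own keep the number low among these compounds. The change on the oxygen also shows that matching size by heavy-atom count is no guide here: trifluoromethyl and isobutyl both have 4 heavy atoms and no ring, yet the exchange gives a large step (a 160-fold higher number from compound 3 to compound 4 (2.20 log units; beyond the scatter)), and nothing available here accounts for a rise of this size.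

The compounds shown leave open whether the high number belongs to the branched isobutyl group in particular or to carbon chains on this oxygen more generally, a question that methoxy, ethoxy and straight butoxy groups could help to settle. They also leave open how an amine or a carboxylic acid on the same aromatic carbon would behave in this assay.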